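The compounds below may be only part of what the source reports. "The series", "measured", "known", "first", "only" and "open" are said of these compounds alone.

In a functional assay on HeLa cells (Homo sapiens) for cytotoxicity, read by neutral red uptake, with a stated time of 3 days (a higher number here means a weaker inhibitor, a lower number a stronger inhibitor), compound 1 `Nc1ccc(-c2cc(=O)c3c(N)c(F)cc(F)c3o2)cc1F` gives only a limit, > 100000 nM, as noted under (the limit of > 100000 nM in this assay, at which 1 of the 3 values shown sits). Compound 2 `COc1c(F)c(N)c2c(=O)cc(-c3ccc(N)c(F)c3)oc2c1F` gives 34000 nM and compound 3 `CN(C)CC(=O)OCc1c(F)c(N)c2c(=O)cc(-c3ccc(N)c(F)c3)oc2c1F` gives 9200 nM, so compound 3 holds the lowest of the two measured numbers, with compound 2 nearest. The measured steps run the same way: an at least 2.9-fold lower number from compound 1 to compound 2 (0.46 log units; beyond the scatter), an at least 10-fold lower number from compound 1 to compound 3 (1.03 log units; beyond the scatter) and a 3.7-fold lower number from compound 2 to compound 3 (0.57 log units; beyond the scatter). Compound 4 `NCc1c(F)c(N)c2c(=O)cc(-c3ccc(N)c(F)c3)oc2c1F` differs from compound 3 by amino in place of (((dimethylamino)methyl)carbonyl)oxy on a saturated chain carbon bound to an aromatic carbon. The steps of an at least 10-fold lower number from compound 1 to compound 3 (1.03 log units; beyond the scatter) and a 3.7-fold lower number from compound 2 to compound 3 (0.57 log units; beyond the scatter) bear on it, as both concern the group that now leaves; part of that gain is expected to be given back, so the step of a 2.0-fold higher number from compound 3 to compound 4 (0.29 log units; within the scatter) is expected upward and modest. Compound 4 is therefore estimated at 18000 nM, between 5000 nM and 70000 nM, in this assay.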

Compound 4, half-maximal inhibitory concentration: 8800 nM
Beside the measured number, compound 4's estimate is 2.0-fold (0.31 log units) above it, within the range that was stated.
By their numbers in this assay, from the lowest: compounds 4 and 3 (each within the scatter of the next); then compound 2. At a limit, above all of these: compound 1.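

At this place, on a saturated chain carbon bound to an aromatic carbon, amino can stand in for (((dimethylamino)methyl)carbonyl)oxy with no change in this assay: a 1.0-fold lower number from compound 3 to compound 4 (0.02 log units; within the scatter). The small aminomethyl group is therefore enough to keep the advantage over methoxy, a 3.9-fold lower number from compound 2 to compound 4 (0.59 log units; beyond the scatter), and over hydrogen, an at least 11-fold lower number from compound 1 to compound 4 (1.05 log units; beyond the scatter). Compound 1 gives only a limit, > 100000 nM.

On these data alone, it remains open whether a hydroxymethyl group, a dimethylaminomethyl group or a longer aminoethyl chain would match aminomethyl here. The role of the amine nitrogen at this place therefore stays undefined.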